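Removing the Ring Amine from the Side Chain

A few compounds are considered here, and "the series" means these few. Any claim that something is new, unique, unknown or untested is made for them only; others in the source may bear on it.

Compound 1 `CCn1c(N)c(-c2nc3ccccc3[nH]2)c2nc(C#N)c(C#N)nc21`: > 50000 nM
Compound 2 `CCN(CC)CCn1c(N)c(-c2nc3ccccc3[nH]2)c2nc(C#N)c(C#N)nc21`: 2490 nM
Compound 3 `N#Cc1nc2c(-c3nc4ccccc4[nH]3)c(N)n(CCN3CCCC3)c2nc1C#N`: 6480 nM

In a functional assay on K562 cells (Homo sapiens) for antiproliferative activity, read by MTT assay, with a stated time of 48 h (on this read-out higher numbers stand for weaker inhibition and lower numbers for stronger inhibition), the result for compound 1 is a limit and not a number: the limit of > 50000 nM in this assay, at which 1 of the 3 values shown sits. Among the two proper numbers, compound 3 stands highest, with compound 2 as its nearest neighbour a 2.6-fold higher number from compound 2 to compound 3 (0.42 log units; beyond the scatter). The unmeasured compound 4 `CCCCn1c(N)c(-c2nc3ccccc3[nH]2)c2nc(C#N)c(C#N)nc21` differs from compound 3 in one place: ethyl in place of pyrrolidin-1-yl on a saturated chain carbon, two bonds along the chain from an aromatic nitrogen. The step that bears on this is the one in which pyrrolidin-1-yl was put in place of hydrogen, an at least 7.7-fold lower number from compound 1 to compound 3 (0.88 log units; beyond the scatter), which was at least modest. Taking the pyrrolidin-1-yl away again in compound 4 is expected to undo that gain, so a large rise in the number is expected, a 6.2-fold higher number from compound 3 to compound 4 (0.79 log units; beyond the scatter). Compound 4 is therefore estimated at 40000 nM, within 10000 nM to 100000 nM.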

Compound 4, half-maximal inhibitory concentration: > 50000 nM
Compound 4 gave a limit, no number; the forecaster's own chance of this, stated with the estimate: 50%; middle value at least 1.2-fold (0.09 log units) away from the limit.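

Compound 4 gives a limit, not a number: the limit of > 50000 nM in this assay, at which 2 of the 4 values shown sit. Replacing the amine at the end of the chain with plain carbon gives an at least 7.7-fold higher number from compound 3 to compound 4 (0.88 log units; beyond the scatter), and the same change gives an at least 20-fold higher number from compound 2 to compound 4 (1.30 log units; beyond the scatter), so a butyl chain does not stand in for either the pyrrolidin-1-yl or the diethylamino compound. The step between the two compounds with limits, compound 1 and compound 4, cannot be read. From the compounds shown here alone, it remains open whether other amines on this chain, such as morpholine, piperidine or dimethylamino, would give a number like those of compound 2 and compound 3, and whether a longer chain carrying the amine would do the same.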